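The source may hold more compounds than are shown below. What is called first, only, known or untested is meant among the compounds shown, and "the series" means these compounds.

Compound 1, `Cc1cccc(-c2nnc(CNc3c(C)n(C)n(-c4ccccc4)c3=O)o2)c1`: 2.39
Compound 2, `Cc1c(NCc2nnc(-c3cccs3)o2)c(=O)n(-c2ccccc2)n1C`: 1.9
Compound 3, `Cc1c(NCc2nnc(-c3ccccc3O)o2)c(=O)n(-c2ccccc2)n1C`: 1.71

These three compounds share one core and differ only in the aromatic group attached to it. In a physicochemical assay for lipophilicity, measured as octanol-water partition (a lower number here means a more polar compound, a higher number a more lipophilic compound), compound 1 gives the highest of the three numbers; compound 2 is nearest, a number 0.49 log units lower from compound 1 to compound 2 (beyond the scatter), and compound 3 is furthest, a number 0.68 log units lower from compound 1 to compound 3 (beyond the scatter). Between compound 2 and compound 3 the gap is a number 0.19 log units lower from compound 2 to compound 3 (within the scatter).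

Compound 4, `Cc1c(NCc2nnc(-c3ccccc3)o2)c(=O)n(-c2ccccc2)n1C`, is not yet measured. It differs from compound 1 in one place: hydrogen in place of methyl on an aromatic carbon. Read one bond further out, the change is 3-methylphenyl to phenyl.

Among the compounds with values here, no measured step removes just this methyl; the two steps from compound 1 each swapped the entire 3-methylphenyl for a different ring and gave modest drops in this assay. The change to compound 4 is smaller than either, so a drop smaller than those is expected, or one at the edge of the scatter. The expected step is a number 0.49 log units lower from compound 1 to compound 4 (beyond the scatter). Compound 4 is therefore estimated at 1.9, between 1.6 and 2.2.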

Compound 4, partition coefficient: 2.02
Estimate against measurement, compound 4: 0.12 log units below; low and high end bracket the measured number.
By their numbers in this assay, from the lowest: compounds 3, 2 and 4 (each within the scatter of the next, the first and the last beyond it); then compound 1.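

Taken alone, hydrogen in place of methyl on this aromatic carbon gives a number 0.37 log units lower from compound 1 to compound 4 (beyond the scatter), so a single methyl carbon on the six-membered ring is enough to move this assay beyond the scatter, something the earlier whole-ring swaps could not isolate. Compound 4 also provides the plain phenyl reference that was missing: a number 0.31 log units higher from compound 3 to compound 4 (beyond the scatter) separates it from the 2-hydroxyphenyl compound, while a number 0.12 log units higher from compound 2 to compound 4 (within the scatter) leaves the thiophen-2-yl and phenyl compounds indistinguishable, so among the rings without a methyl, only the 2-hydroxyphenyl compound stands apart from phenyl, and only from phenyl, not from thiophen-2-yl. Nothing measured here explains why these steps have the sizes they do.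

The compounds shown cover only methyl and hydrogen at this carbon, so the effect of an amine, a carboxylic acid or a longer chain such as propyl in the same place remains unknown. As far as these compounds go, it also remains open whether a methyl on another carbon of the ring, or on a thiophen-2-yl ring, would give a step of similar size.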